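Replacing chloro with trifluoromethoxy in the series

The compounds below may be only part of what the source reports. "The series", "measured", "known", "first", "only" and "open" are said of these compounds alone.

Values so far in a functional assay on HCT-116 cells (Homo sapiens) for antiproliferative activity, read by MTT assay (on this read-out lower numbers stand for stronger inhibition and higher numbers for weaker inhibition), are as follows
- compound 1 `Cn1c(=O)c(=O)n(C2CCCC2)c2nc(N/N=C/c3ccc(Cl)cc3)ncc21` gives 9810 nM 
- compound 2 `Cn1c(=O)c(=O)n(C2CCCC2)c2nc(N/N=C/c3cccc(Cl)c3Cl)ncc21` gives 26400 nM 
- compound 3 `Cn1c(=O)c(=O)n(C2CCCC2)c2nc(N/N=C/c3cccc(O)c3)ncc21` gives 37200 nM 

Compound 1 holds the lowest of the three numbers, beyond the scatter from both others. Compound 4 `Cn1c(=O)c(=O)n(C2CCCC2)c2nc(N/N=C/c3ccc(OC(F)(F)F)cc3)ncc21` differs from it by one group (trifluoromethoxy in place of chloro on an aromatic carbon), with trifluoromethoxy in place of chloro on an aromatic carbon, para to a large group. For the measured compounds named here, only two measured steps bear on this, and only indirectly. The steps of a 2.7-fold higher number from compound 1 to compound 2 (0.43 log units; beyond the scatter) and a 3.8-fold higher number from compound 1 to compound 3 (0.58 log units; beyond the scatter) are both modest and both upward, but each replaces the whole 4-chlorophenyl, and neither tests trifluoromethoxy. In this assay a small upward shift is therefore expected, not one clearly beyond the scatter. The estimated step is a 1.3-fold higher number from compound 1 to compound 4 (0.12 log units; within the scatter) in this reading. For compound 4 the expected value is 13000 nM, with an estimated range of 5500 nM to 31000 nM here.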

Compound 4, half-maximal inhibitory concentration: 6150 nM
Estimate against measurement, compound 4: 2.1-fold (0.33 log units) above; the measured number falls inside the stated range.
By their numbers in this assay, from the lowest: compounds 4 and 1 (each within the scatter of the next); then compounds 2 and 3 (each within the scatter of the next).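

In this assay, trifluoromethoxy in place of chloro on an aromatic carbon, para to a large group, gives a 1.6-fold lower number from compound 1 to compound 4 (0.20 log units; within the scatter). This place therefore accepts a group of 5 heavy atoms where chloro has 1, with no shift beyond the scatter, which the whole-ring replacements in compounds 2 and 3 could not show. No evidence on hand accounts for this result.

Open, on these data alone, is how an amine or a carboxylic acid at this place would read out. Also open, as far as these compounds go, is how the unsubstituted phenyl compares with compound 1.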